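Moving the Methoxy Group Around the Pendant Aryl Ring

This account rests on a few compounds, and the source may have more. Where it says the series, first, only, none or still open, it means among the compounds named here.

Compound 1 `COc1ccc(-c2nn(Cc3ccc(NC(=O)OCCCCN(C)C)cc3)c(=O)c3ccccc23)cc1` in an ADME assay on Huh-7 cells (Homo sapiens) for cytotoxicity, read by MTT assay, with a stated time of 48 h (a lower number here means that less compound is tolerated, a higher number that more compound is tolerated), gives 20300 nM.
Compound 2 `CN(C)CCCCOC(=O)Nc1ccc(Cn2nc(-c3ccc(C#N)cc3)c3ccccc3c2=O)cc1` in this assay gives 37000 nM.
Compound 3 `COc1cccc(-c2nn(Cc3ccc(NC(=O)OCCCCN(C)C)cc3)c(=O)c3ccccc23)c1` in this assay gives 17600 nM.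

Compound 3 stands lowest of the three numbers: a 1.2-fold lower number from compound 1 to compound 3 (0.06 log units; within the scatter) separates it from compound 1, and a 2.1-fold lower number from compound 2 to compound 3 (0.32 log units; beyond the scatter) separates it from compound 2. Compound 4 `COc1ccccc1-c1nn(Cc2ccc(NC(=O)OCCCCN(C)C)cc2)c(=O)c2ccccc12` differs from compound 3 by 2-methoxyphenyl in place of 3-methoxyphenyl on an aromatic carbon. Going by the values given here, the one measured step that bears on this, a shift of the same methoxy group around the ring, is a 1.2-fold lower number from compound 1 to compound 3 (0.06 log units; within the scatter); the swap of methoxy for cyano, a 1.8-fold higher number from compound 1 to compound 2 (0.26 log units; within the scatter), is a different kind of change. Compound 4 is therefore expected to show a 1.0-fold higher number from compound 3 to compound 4 (0.01 log units; within the scatter), with no step beyond the scatter in this assay. The estimate for compound 4 is 18000 nM, with a range from 9000 nM to 38000 nM.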

Compound 4, half-maximal cytotoxic concentration: 44800 nM
The estimate for compound 4 lay 2.5-fold (0.40 log units) below the measured number; measured number above the stated range.
By their numbers in this assay, from the lowest: compounds 3, 1, 2 and 4 (each within the scatter of the next, the first and the last beyond it).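

In this assay, the placement of the methoxy group on the pendant aryl ring can shift the number: 2-methoxyphenyl gives a 2.5-fold higher number from compound 3 to compound 4 (0.41 log units; beyond the scatter) and a 2.2-fold higher number from compound 1 to compound 4 (0.34 log units; beyond the scatter), whereas the earlier move between the other two placements did not exceed the scatter. With 4-cyanophenyl as the comparison, there is a 1.2-fold higher number from compound 2 to compound 4 (0.08 log units; within the scatter), so the two groups cannot be told apart here. Nothing available explains the effect of this placement. As far as these compounds go, whether it is particular to methoxy stays open; a 2-ethoxyphenyl or 2-aminophenyl group at the same place would test this.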